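The source may hold more compounds than are shown below. What is called first, only, known or untested is meant among the compounds shown, and "the series" means these compounds.

Compound 1 `CN1CCC(C(=O)N2Cc3c(NC(=O)Nc4cccc(F)c4)n[nH]c3C2(C)C)CC1` is the reference. In a functional assay on A2780 cells (Homo sapiens) for antiproliferative activity, read by fluorescence, with a stated time of 72 h (on this read-out lower numbers stand for stronger inhibition and higher numbers for weaker inhibition), compound 1 gives 350 nM, the highest of the two numbers shown, while compound 3 `CCN1CCC(C(=O)N2Cc3c(NC(=O)c4ccc(F)cc4)n[nH]c3C2(C)C)CC1` gives 290 nM, a gap within the scatter. Compound 2 `CC(=O)N1CCN(C(=O)N2Cc3c(NC(=O)c4ccc(F)cc4)n[nH]c3C2(C)C)CC1` reaches only the assay limit (the limit of > 10000 nM in this assay, at which 1 of the 3 values shown sits), reported as > 10000 nM. Within the data shown here, the single measured step, an at least 34-fold lower number from compound 2 to compound 3 (1.53 log units; beyond the scatter), concerns a different part of the molecule and does not bear directly on the move to compound 4 `CN1CCC(C(=O)N2Cc3c(NC(=O)c4ccc(C(F)(F)F)cc4)n[nH]c3C2(C)C)CC1`. That move is 4-(trifluoromethyl)phenyl in place of (3-fluorophenyl)amino on a carbonyl carbon. Compounds 1 and 3 already carry different groups on this carbonyl carbon, yet their numbers sit close together. On that basis no step beyond the scatter is expected. Compound 4 is therefore estimated at 400 nM (range 150 nM to 1200 nM), an expected step of a 1.1-fold higher number from compound 1 to compound 4 (0.06 log units; within the scatter).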

Compound 4, half-maximal inhibitory concentration: 60 nM
Compound 4: the middle estimate sits 6.7-fold (0.82 log units) above what was measured; the measured number lies below the stated range.
By their numbers in this assay, from the lowest: compound 4; then compounds 3 and 1 (each within the scatter of the next). At a limit, above all of these: compound 2.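

In this assay, the group on this carbonyl carbon can move the number beyond the scatter: 4-(trifluoromethyl)phenyl in place of (3-fluorophenyl)amino gives a 5.8-fold lower number from compound 1 to compound 4 (0.77 log units; beyond the scatter). The change takes away the hydrogen-bond donor of the leaving group and also alters the ring's substituent, and this one step cannot separate the two. Nothing measured here accounts for the size of the step. Still open, on these data alone, is how a (4-(trifluoromethyl)phenyl)amino or a 4-methoxyphenyl group on this carbonyl carbon would read, so the amino link and the trifluoromethyl group remain untold apart.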